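Notes on replacing the 4-chloro-3-(trifluoromethyl)phenyl group of compound 2

The compounds below may be only part of what the source reports. "The series", "measured", "known", "first", "only" and "open" are said of these compounds alone.

Values measured in a functional assay on SW-620 cells (Homo sapiens) for inhibition, read by MTT assay, with a stated time of 4 days; a lower number here means a stronger inhibitor, a higher number a weaker inhibitor
compound 1 `COc1ccc(C(=NNC(=O)NNC(=O)NCCCC(C)Nc2cc(OC)cc3cccnc23)c2ccc(OC)cc2)cc1` gives >= 100000 nM
compound 2 `COc1cc(NC(C)CCCNC(=O)NNC(=O)Nc2ccc(Cl)c(C(F)(F)F)c2)c2ncccc2c1` gives 15000 nM
compound 3 `CCOC(=O)N(C)C(c1ccccc1)c1ccccc1` gives 27000 nM

Compound 1 reads >= 100000 nM as a limit of the assay, not a number. Only compound 2 and compound 3 carry true numbers, and compound 2 (15000 nM) and compound 3 (27000 nM) lie within the scatter of each other, so the two are not ranked.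

Compound 4 `COc1cc(NC(C)CCCNC(=O)NNC(=O)NC(CO)(CO)CO)c2ncccc2c1` has not yet been measured. Its change from compound 2 is 2-hydroxy-1,1-bis(hydroxymethyl)ethyl in place of 4-chloro-3-(trifluoromethyl)phenyl on an amide-type nitrogen.

Among the measured compounds shown here, no measured pair isolates a change at this place, so the step expected in this assay rests on judgement, starting from compound 2 at 15000 nM and without a measured step to support it. The step expected is a 3.3-fold higher number from compound 2 to compound 4 (0.52 log units; beyond the scatter) and points toward a weaker inhibitor, beyond the scatter but moderate in size. A reading at the limit of >= 100000 nM in this assay, at which 1 of the 3 values shown sits, as for compound 1 cannot be excluded for compound 4. For compound 4 the estimated value is 50000 nM (expected range 18000 nM to 100000 nM).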

Compound 4, half-maximal inhibitory concentration: > 100000 nM
Compound 4 gave a limit, no number; the forecaster's own chance of this, stated with the estimate: 35%; middle value at least 2.0-fold (0.30 log units) from the limit.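

Among the compounds shown here, replacing 4-chloro-3-(trifluoromethyl)phenyl on the amide-type nitrogen with 2-hydroxy-1,1-bis(hydroxymethyl)ethyl gives, in this assay, an at least 6.6-fold higher number from compound 2 to compound 4 (0.82 log units; beyond the scatter), the first reading for a change at this position, and it is beyond the scatter. Among the compounds that share the core of compound 2, only compound 2 now carries a true number, while compound 1 and compound 4 both read as limits, so the aromatic 4-chloro-3-(trifluoromethyl)phenyl group is the only group at this end of the molecule shown with a measurable value. Compound 4 reads as a limit and not a number: the limit of > 100000 nM in this assay, at which 1 of the 4 values shown sits.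

The change removes the aromatic ring and brings in three hydroxyl groups in one step, so the compounds shown cannot tell which of the two goes with the weaker reading, and no measured property is available to give a cause. A plain phenyl, a cyclohexyl or a tert-butyl group on this nitrogen would separate the loss of the ring from the entry of the hydroxyl groups.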